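Compound 2 and a Swap on Its Aromatic Ring

This account rests on a few compounds, and the source may have more. Where it says the series, first, only, none or still open, it means among the compounds named here.

Compound 4 `COC(=O)c1ccc(CN(CCCc2c(N)nc(N)nc2O)c2cc(F)c([N+](=O)[O-])cc2[N+](=O)[O-])cc1` has not yet been measured, but three related compounds have been tested in a functional assay on CCRF-CEM cells (Homo sapiens) for cytotoxicity, in the absence of a further agent; a higher number here means a weaker inhibitor, a lower number a stronger inhibitor. Among the measured compounds shown here, compound 2 `Nc1nc(N)c(CCCN(Cc2ccc(NC(CCC(=O)O)C(=O)O)cc2)c2cc(F)c([N+](=O)[O-])cc2[N+](=O)[O-])c(O)n1` gives 51000 nM, the only true number in this small set. Compound 1 `COC(=O)c1ccc(CN(CCCc2c(N)nc(N)nc2O)c2cc(F)cc(F)c2[N+](=O)[O-])cc1` reads > 100000 nM, which is a limit of the assay and not a number. Compound 3 `Nc1nc(N)c(CCCNc2cc(F)ccc2[N+](=O)[O-])c(O)n1` reads > 100000 nM, which is also a limit. Compound 2 therefore offers the only firm reference point, while the limit of > 100000 nM in this assay, at which 2 of the 3 values shown sit, marks the other two results.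

The structural change from compound 2 to compound 4 is methoxycarbonyl in place of (1,3-dicarboxypropyl)amino on an aromatic carbon. For the measured compounds named here, no two measured compounds differ in just one place, so no measured step shows what a change like this does in this assay.

Compound 2 at 51000 nM is the natural anchor, so compound 4 is expected to stay close to it, with no clear direction and no shift beyond the usual scatter. The expected step of a 1.1-fold lower number from compound 2 to compound 4 (0.05 log units; within the scatter) is small, though its uncertainty is wide. For compound 4 the estimated value is 45000 nM, with an expected range from 10000 nM to 100000 nM.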

Compound 4, half-maximal inhibitory concentration: 4300 nM
For compound 4 the middle estimate is 10-fold (1.02 log units) above the measured one, and the stated range ends above it.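

The swap of (1,3-dicarboxypropyl)amino for methoxycarbonyl, on an aromatic carbon para to a large group, gives a 12-fold lower number from compound 2 to compound 4 (1.07 log units; beyond the scatter) in this assay. Among the compounds shown here, this is the first measured step in the set, and it shows that the group at this position can shift the result well beyond the scatter, with the methoxycarbonyl compound as the stronger inhibitor. Still, the entering group differs from the leaving one in several counted ways at once, with fewer heavy atoms and no hydrogen-bond donors, so this single pair cannot say which difference matters, and the other two compounds offer no firm number to test it against: the limit of > 100000 nM in this assay, at which 2 of the 4 values shown sit.

Going by these compounds, it remains open whether methoxycarbonyl itself matters or whether the gain comes from losing the larger (1,3-dicarboxypropyl)amino group. A plain carboxylic acid or a primary amide at the same position would help to separate these two readings, and a longer alkyl ester would show how much room for change this position allows.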